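Ethoxy for piperazin-1-yl on the shared core

The source may report more compounds than this note shows. Statements on the series, on what has been measured and on what is new or still open speak of the compounds shown alone.

In a functional assay on A549 cells (Homo sapiens) for inhibition, read by MTT assay, with a stated time of 72 h (a lower number here means a stronger inhibitor, a higher number a weaker inhibitor), compound 2 `CC(C)(C)n1cc2c(n1)C(=O)CC1(CCN(C(=O)c3cc(N4CCNCC4)nc4ccccc34)CC1)O2` gives > 10000 nM, which is a limit of the assay and not a number. Compound 1 `COc1ccc(-c2cc(C(=O)N3CCC4(CC3)CC(=O)c3nn(C(C)(C)C)cc3O4)c3ccccc3n2)cc1` gives 3740 nM. Among the compounds with values here, the one measured step on this aromatic carbon, an at least 2.6-fold higher number from compound 1 to compound 2 (0.42 log units; beyond the scatter), came with piperazin-1-yl in place of 4-methoxyphenyl. Compound 3 `CCOc1cc(C(=O)N2CCC3(CC2)CC(=O)c2nn(C(C)(C)C)cc2O3)c2ccccc2n1` carries ethoxy in place of piperazin-1-yl on an aromatic carbon. On these data alone, a step of similar size towards a lower number is expected, by reversal of the step to compound 2, though its true size remains open. The estimate implies an at least 2.0-fold lower number from compound 2 to compound 3 (0.30 log units; that floor lies within the scatter). Compound 3 is expected at 5000 nM, within an estimated range of 2000 nM to 12000 nM.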

Compound 3, half-maximal inhibitory concentration: > 10000 nM
Compound 3 ended at the assay's limit; the forecaster's own chance of this, stated with the estimate: 25%; middle value at least 2.0-fold (0.30 log units) away from the limit.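

On this aromatic carbon next to the ring nitrogen, ethoxy in place of 4-methoxyphenyl also gives a weaker result in this assay: an at least 2.6-fold higher number from compound 1 to compound 3 (0.42 log units; beyond the scatter). Among the compounds shown, a measured number therefore stands only with 4-methoxyphenyl, and both ethoxy and piperazin-1-yl end at a limit of the assay. The step from compound 2 to compound 3 cannot be read because both values are limits: the limit of > 10000 nM in this assay, at which 2 of the 3 values shown sit.

On these data alone, whether the gain belongs to the methoxy group or to the aromatic ring itself stays open. An unsubstituted phenyl or a 4-fluorophenyl at this position would separate the two.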